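Methoxy for methyl on the hydroxy-bearing core of compound 3

The source may report more compounds than this note shows. Statements on the series, on what has been measured and on what is new or still open speak of the compounds shown alone.

Compound 1 `Cc1ccc(-c2nnc(SCCn3c([N+](=O)[O-])cnc3C)o2)cc1` and compound 2 `COc1ccc(-c2nnc(SCCn3c([N+](=O)[O-])cnc3C)o2)cc1` differ only by methoxy in place of methyl on an aromatic carbon. In a functional assay on SGC-7901 cells (Homo sapiens) for cytotoxicity, read by MTT assay, with a stated time of 48 h (a lower number here means a stronger inhibitor, a higher number a weaker inhibitor), compound 1 gives 12500 nM, and in this assay compound 2 gives 10200 nM, so that a 1.2-fold lower number from compound 1 to compound 2 (0.09 log units; within the scatter). Compound 3 `Cc1ccc(-c2nnc(SCCn3c([N+](=O)[O-])cnc3C)o2)c(O)c1` differs from compound 1 by hydroxy in place of hydrogen on an aromatic carbon. In this assay compound 3 gives 36700 nM; this is a 2.9-fold higher number from compound 1 to compound 3 (0.47 log units; beyond the scatter) and a 3.6-fold higher number from compound 2 to compound 3 (0.56 log units; beyond the scatter), the highest number of the three.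

Compound 4 `COc1ccc(-c2nnc(SCCn3c([N+](=O)[O-])cnc3C)o2)c(O)c1` is not yet measured. It differs from compound 3 by methoxy in place of methyl on an aromatic carbon. This is the same kind of change as from compound 1 to compound 2, not the same: in compound 3 the place is meta to a hydroxy group as well as para to a large group, whereas in compound 1 it is only para to a large group. Compound 4 is expected to show a 1.2-fold lower number from compound 3 to compound 4 (0.09 log units; within the scatter), because a 1.2-fold lower number from compound 1 to compound 2 (0.09 log units; within the scatter) lies within the scatter. Compound 4 is therefore estimated at 30000 nM, with a likely range from 15000 nM to 70000 nM.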

Compound 4, half-maximal inhibitory concentration: 11700 nM
For compound 4 the middle estimate is 2.6-fold (0.41 log units) above the measured one; the whole stated range lies above it.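

In this assay, methoxy in place of methyl on the hydroxy-bearing core gives a 3.1-fold lower number from compound 3 to compound 4 (0.50 log units; beyond the scatter), and hydroxy in place of hydrogen on the core of compound 2 gives a 1.1-fold higher number from compound 2 to compound 4 (0.06 log units; within the scatter). The methoxy change is larger on the hydroxy-bearing core by its printed values, yet the gap between the two cores stays inside what two such steps can scatter, so neither a core-dependent effect nor a clean carry-over is established: the same change on two cores in this assay, a 1.2-fold lower number (0.09 log units; within the scatter) from compound 1 to compound 2 and a 3.1-fold lower number (0.50 log units; beyond the scatter) from compound 3 to compound 4, 2.6-fold (0.41 log units) apart, within the scatter of two such steps The hydroxy change reads the same way, and this single pair of cores gives no firm ground for predicting either change on another core: the same change on two cores in this assay, a 2.9-fold higher number (0.47 log units; beyond the scatter) from compound 1 to compound 3 and a 1.1-fold higher number (0.06 log units; within the scatter) from compound 2 to compound 4, 2.6-fold (0.41 log units) apart, within the scatter of two such steps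

As far as these compounds go, whether either step holds with other groups at the same place, such as chlorine or an amine, remains open. Also open, from the compounds shown here alone, is how a longer chain in the sulfur-bearing link would alter these steps.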